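A few compounds are considered here, and "the series" means these few. Any claim that something is new, unique, unknown or untested is made for them only; others in the source may bear on it.

Measured so far, in an ADME assay on Vero cells (Chlorocebus sabaeus) for cytotoxicity, with a stated time of 72 h; on this read-out higher numbers stand for weaker inhibition and lower numbers for stronger inhibition:

Compound 1 `N#Cc1ccc(-c2cc(CO[C@@H]3COc4nc([N+](=O)[O-])cn4C3)on2)cc1`: > 128000 nM, a limit of the assay.
Compound 2 `O=[N+]([O-])c1cn2c(n1)OC[C@@H](OCc1cc(-c3ccc(F)cc3)no1)C2`: > 128000 nM, a limit of the assay.
Compound 3 `N#Cc1ccc(-n2cc(CO[C@@H]3COc4nc([N+](=O)[O-])cn4C3)nn2)cc1`: > 128000 nM, a limit of the assay.

All three values stand at the limit of > 128000 nM in this assay, at which 3 of the 3 values shown sit; none is a number. Compound 2 differs from compound 1 by fluoro in place of cyano on an aromatic carbon, and the step that the two limits leave unreadable from compound 1 to compound 2 cannot be read, since both ends are limits. Compound 3 and compound 1 differ in their cores, and that difference between the two cores is not broken down here.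

Compound 4 `O=[N+]([O-])c1cn2c(n1)OC[C@@H](OCc1cn(-c3ccc(F)cc3)nn1)C2` is not yet measured in this assay. It differs from compound 3 by fluoro in place of cyano on an aromatic carbon, the same change as that from compound 1 to compound 2, made on the core of compound 3 instead; the place is described in the same words for both pairs, so it is the same change, occurring twice among the compounds shown.

Among the compounds with values here, nothing in the measured values gives a direction for this change: the one example of it is unreadable, and every value shown sits at the limit. The expectation for compound 4 is therefore that it again stays at the limit, with a step that the limit leaves unreadable from compound 3 to compound 4 that would itself remain unreadable. Compound 4 is estimated at 250000 nM in this assay, with a range from 100000 nM to 700000 nM, and most likely reported only as a limit.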

Compound 4, half-maximal inhibitory concentration: > 128000 nM
Compound 4: only a limit was reported (the forecaster's own chance of this, stated with the estimate: 90%); the middle value lies beyond the limit too.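

In this assay, compound 3 and compound 4 each stand only as a limit of the assay, so no new step can be read, and the fluoro-for-cyano change stays as unreadable here as between compound 1 and compound 2. All values shown sit at one point: the limit of > 128000 nM in this assay, at which 4 of the 4 values shown sit. The compounds shown leave open whether either this change or the difference between the cores affects the read-out at all.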